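This account rests on a few compounds, and the source may have more. Where it says the series, first, only, none or still open, it means among the compounds named here.

Measured so far in an assay for inhibition of HSP60/HSP10 (Homo sapiens), with a stated time of 60 min; on this read-out higher numbers stand for weaker inhibition and lower numbers for stronger inhibition:
compound 1 `O=S(=O)(Nc1ccc2oc(-c3ccc(NS(=O)(=O)c4ccc(Cl)s4)cc3)nc2c1)c1ccc(Cl)c(Cl)c1` gives 4700 nM;
compound 2 `O=S(=O)(Nc1ccc2oc(-c3ccc(NS(=O)(=O)c4cccc5nonc45)cc3)nc2c1)c1ccc(Cl)s1` gives 11000 nM;
compound 3 `O=S(=O)(Nc1ccc2oc(-c3ccc(NS(=O)(=O)c4ccc(Cl)s4)cc3)nc2c1)c1cccc(C(F)(F)F)c1` gives 5000 nM.

Compound 2 stands highest of the three numbers, beyond the scatter from both compound 3 and compound 1, which lie within the scatter of each other. Among the measured compounds shown here, the one step between measured compounds that differ in one place is a 1.1-fold higher number from compound 1 to compound 3 (0.03 log units; within the scatter), so exchanging one carbon-only aromatic group for another on a sulfonyl sulfur left this assay unmoved.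

Compound 4 `O=S(=O)(Nc1ccc(-c2nc3cc(NS(=O)(=O)c4ccc(Cl)s4)ccc3o2)cc1)c1cccc(C(F)(F)F)c1` is obtained from compound 2 by the change (a group of 10 heavy atoms (7 carbon, 3 fluorine; one six-membered aromatic ring of carbon only) in place of a group of 9 heavy atoms (6 carbon, 2 nitrogen, 1 oxygen; one five-membered aromatic ring with 3 hetero atoms, one six-membered aromatic ring of carbon only), on a sulfonyl sulfur). For the measured compounds named here, no measured step covers the departure of the five-membered aromatic ring with 3 hetero atoms; what is known is that compound 3, carrying 3-(trifluoromethyl)phenyl on a sulfonyl sulfur, sits below compound 2 by more than the scatter, and that compounds 1 and 3 agree. The expectation is therefore a modest lowering, a 2.0-fold lower number from compound 2 to compound 4 (0.30 log units; within the scatter), bringing compound 4 toward the level of compounds 1 and 3. Compound 4 is estimated at 5500 nM, with a range of 2500 nM to 12000 nM.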

Compound 4, half-maximal inhibitory concentration: 4500 nM
Estimate against measurement, compound 4: 1.2-fold (0.09 log units) above; measured number inside the range.
By their numbers in this assay, from the lowest: compounds 4, 1 and 3 (each within the scatter of the next); then compound 2.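

In this assay, the sulfonyl sulfur carrying the group with the five-membered aromatic ring with 3 hetero atoms in compound 2 responds to substitution: 3-(trifluoromethyl)phenyl in that place gives a 2.4-fold lower number from compound 2 to compound 4 (0.39 log units; beyond the scatter), a modest step but one beyond the scatter. Among the compounds shown here, the earlier step, a 1.1-fold higher number from compound 1 to compound 3 (0.03 log units; within the scatter), lay within the scatter and concerned the other sulfonyl sulfur of the shared core, so this is the first sign that an exchange on a sulfonyl sulfur can move the read-out. No supporting measurement on hand accounts for this step.

A single exchange cannot separate the departure of the leaving group from the arrival of 3-(trifluoromethyl)phenyl. Plain phenyl would help to divide the two, and a phenyl bearing a carboxylic acid or an amine on the same sulfonyl sulfur would show how far the step extends.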